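Phenyl for Methyl at the Amide Chain

The source may hold more compounds than are shown below. What is called first, only, known or untested is meant among the compounds shown, and "the series" means these compounds.

Measured so far in an assay on isolated protein for displacement of a labelled ligand from Adrenergic receptor alpha-1 (Rattus norvegicus); on this read-out lower numbers stand for stronger inhibition and higher numbers for weaker inhibition:
compound 1, `CCNC(=O)C1CCN(c2nc(N)c3cc(OC)c(OC)cc3n2)CC1`, gives 1.64 nM;
compound 2, `CCCCNC(=O)C1CCN(c2nc(N)c3cc(OC)c(OC)cc3n2)CC1`, gives 0.67 nM;
compound 3, `CCN(CC)C(=O)C1CCN(c2nc(N)c3cc(OC)c(OC)cc3n2)CC1`, gives 1.11 nM.

Compound 1 stands highest of the three numbers. Compound 3 lies closest to it, within the scatter, while compound 2 lies furthest, beyond it. Compound 4, `COc1cc2nc(N3CCC(C(=O)NCc4ccccc4)CC3)nc(N)c2cc1OC`, differs from compound 1 by phenyl in place of methyl on a saturated chain carbon bound to an amide-type nitrogen. The step that bears most on this change is a 2.4-fold lower number from compound 1 to compound 2 (0.39 log units; beyond the scatter), where ethyl entered on the saturated chain carbon two bonds along from the amide-type nitrogen; a 1.5-fold lower number from compound 1 to compound 3 (0.17 log units; within the scatter) lies within the scatter. A modest lower number is therefore expected for compound 4, estimated at 0.8 nM with a range from 0.3 nM to 2.5 nM. That expected estimate amounts to a 2.1-fold lower number from compound 1 to compound 4 (0.31 log units; beyond the scatter).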

Compound 4, inhibition constant: 0.22 nM
For compound 4 the middle estimate is 3.6-fold (0.56 log units) above the measured one, outside the stated range (below it).
By their numbers in this assay, from the lowest: compound 4; then compounds 2, 3 and 1 (each within the scatter of the next, the first and the last beyond it).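

A phenyl ring at this chain carbon goes with a lower number than every open chain shown. Benzylamino stands below ethylamino (a 7.5-fold lower number from compound 1 to compound 4 (0.87 log units; beyond the scatter)), below diethylamino (a 5.0-fold lower number from compound 3 to compound 4 (0.70 log units; beyond the scatter)), and even below butylamino (a 3.0-fold lower number from compound 2 to compound 4 (0.48 log units; beyond the scatter)), which had itself improved on ethylamino. Nothing measured here explains this gain.

From the compounds shown here alone, it remains open whether the ring itself matters or simply the larger group. A phenethyl group, a pyridylmethyl group or an open heptyl chain in place of benzyl could separate these possibilities.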